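Compound 1 to compound 4: an indolyl exchange

This account rests on a few compounds, and the source may have more. Where it says the series, first, only, none or still open, it means among the compounds named here.

Among the measured compounds shown here, in a functional assay on DU-145 cells (Homo sapiens) for inhibition, read by trypan blue exclusion, with a stated time of 72 h (a higher number here means a weaker inhibitor, a lower number a stronger inhibitor), compound 1 (`COc1ccc(Nc2ncc3cc(S(=O)(=O)c4ccc(C)cc4)c(=O)n(C)c3n2)cc1`) gives 100000 nM, the highest of the three numbers so far. Compound 3 (`COc1ccc(Nc2ncc3cc(S(=O)(=O)c4ccc(Cl)cc4)c(=O)n(C)c3n2)cc1`) gives 30000 nM, and compound 2 (`O=c1c(S(=O)(=O)c2ccc(F)cc2F)cc2cnc(Nc3ccc4[nH]ccc4c3)nc2n1C1CCCC1`) gives 5000 nM, the furthest from compound 1.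

Compound 4 (`Cc1ccc(S(=O)(=O)c2cc3cnc(Nc4ccc5cc[nH]c5c4)nc3n(C)c2=O)cc1`) keeps the core of compound 1 and carries 1H-indol-6-yl in place of 4-methoxyphenyl on a nitrogen on an aromatic ring.

For the measured compounds named here, only one single-place step has been measured, a 3.3-fold lower number from compound 1 to compound 3 (0.52 log units; beyond the scatter), a modest one. It swaps chloro for methyl on an aromatic carbon, so it shows the size of a single change in this small set but says nothing direct about the new group. Compound 2, at 5000 nM, differs from compound 1 in more than one place and serves only as a loose guide that much lower numbers are reachable. Going by the values given here, no measured step isolates the exchange at this nitrogen, so the direction rests on thin evidence.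

A modest move towards stronger inhibition in this assay is expected, with the estimated step being a 3.3-fold lower number from compound 1 to compound 4 (0.52 log units; beyond the scatter). For compound 4 the estimated value is 30000 nM, with an expected range of 8000 nM to 100000 nM.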

Compound 4, half-maximal inhibitory concentration: 15000 nM
The estimate for compound 4 lay 2.0-fold (0.30 log units) above the measured number; measured number inside the range.
By their numbers in this assay, from the lowest: compound 2; then compounds 4 and 3 (each within the scatter of the next); then compound 1.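

In this assay, among the compounds shown here, the first reading at this place gives a 6.7-fold lower number from compound 1 to compound 4 (0.82 log units; beyond the scatter) on exchanging 4-methoxyphenyl for 1H-indol-6-yl on a nitrogen on an aromatic ring. For the compounds shown here, the only earlier single-place step, a 3.3-fold lower number from compound 1 to compound 3 (0.52 log units; beyond the scatter) for chloro in place of methyl on an aromatic carbon, said nothing about this nitrogen, so the series now has a measured change at each of these two places, both modest and both towards lower numbers. The entering 1H-indol-6-yl brings a five-membered aromatic ring and a hydrogen-bond donor while the methoxy oxygen leaves, and no measurement on hand separates these differences or accounts for the step.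

Open, as far as these compounds go, is how 1-methyl-1H-indol-6-yl, which keeps both rings but replaces the indole hydrogen with a methyl group, or a 4-aminophenyl group would read on the same nitrogen. Also open is whether the indolyl exchange gives a step of similar size on the chloro background of compound 3, since the step shown here stands on the methyl background of compound 1 alone.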